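Two Ring Stereocentres, Defined in Turn

The source may report more compounds than this note shows. Statements on the series, on what has been measured and on what is new or still open speak of the compounds shown alone.

In a functional assay on CCRF-CEM cells (Homo sapiens) for inhibition (on this read-out higher numbers stand for weaker inhibition and lower numbers for stronger inhibition), compound 1 `C[C@]1(CO)OC[C@@H](n2ccc(N)nc2=O)O1` gives 30000 nM. Compound 2 `CC1(CO)OCC(n2ccc(N)nc2=O)O1`, drawn without a configuration at either saturated ring carbon, gives 30000 nM, and the step of no change at the digits printed from compound 1 to compound 2 (within the scatter) stays within the scatter, which is consistent with the fact that one of compounds 1 and 2 is drawn with a defined configuration and the other without, at the place where they differ. Compound 3 `C[C@]1(CO)OCC(n2ccc(N)nc2=O)O1` reaches only a limit of the assay, > 100000 nM. The steps of an at least 3.3-fold higher number from compound 1 to compound 3 (0.52 log units; beyond the scatter) and an at least 3.3-fold higher number from compound 2 to compound 3 (0.52 log units; beyond the scatter) are each beyond the scatter, and their true size is bounded only by the limit of > 100000 nM in this assay, at which 1 of the 3 values shown sits. Compound 4 `CC1(CO)OC[C@@H](n2ccc(N)nc2=O)O1` has the same atoms and bonds as compound 3 and differs in which saturated ring carbon carries a drawn configuration: the two compounds have the same atoms and bonds; at least one stereo element is drawn with a configuration in one of them and without one in the other: 2 of 2 stereo elements differ; a stereocentre at a saturated ring carbon is drawn S in compound 3 and without a configuration in compound 4; a stereocentre at a saturated ring carbon is drawn without a configuration in compound 3 and S in compound 4. The centre that is defined in compound 4 is drawn S, as it is in compound 1. Of the measured steps, no change at the digits printed from compound 1 to compound 2 (within the scatter) was flat and an at least 3.3-fold higher number from compound 2 to compound 3 (0.52 log units; beyond the scatter) rose beyond the scatter, so the number for compound 4 is expected nearer to compounds 1 and 2 than to the limit of compound 3, though a second limit cannot be excluded. Compound 4 is therefore estimated at 50000 nM, within 20000 nM to 120000 nM, an expected step of an at least 2.0-fold lower number from compound 3 to compound 4 (0.30 log units; that floor lies within the scatter) downward.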

Compound 4, half-maximal inhibitory concentration: > 100000 nM
Compound 4: a limit, no number; the forecaster's own chance of this, stated with the estimate: 35%; middle value at least 2.0-fold (0.30 log units) from the limit.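

Like compound 3, compound 4 stands only at a limit in this assay, > 100000 nM, and the step between those two cannot be read. The S centre that compound 4 shares with compound 1 does not hold it at the level of compound 1, as an at least 3.3-fold higher number from compound 1 to compound 4 (0.52 log units; beyond the scatter) shows, and an at least 3.3-fold higher number from compound 2 to compound 4 (0.52 log units; beyond the scatter) reaches the same distance from the compound drawn without any configuration. Each ring centre drawn alone now ends at the limit, while compounds 1 and 2 do not, and the only difference behind these steps lies in how configuration is drawn: the fact that one of compounds 1 and 4 is drawn with a defined configuration and the other without, at the place where they differ

Going by these compounds, what numbers compounds 3 and 4 would give past the limit stays open. Also open, on these data alone, is how a carboxylic acid in place of the hydroxymethyl group would read in this assay.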